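Formyl to diethylcarbamoyl on the diaminoquinazoline series

The compounds below may be only part of what the source reports. "The series", "measured", "known", "first", "only" and "open" are said of these compounds alone.

Three compounds with a shared core have numbers in an assay on isolated protein for inhibition of Dihydrofolate reductase (Homo sapiens), read by spectrophotometry, using NADPH, with a stated time of 10 min; a higher number here means a weaker inhibitor, a lower number a stronger inhibitor. Compound 1 `CCOc1ccc(Cl)cc1-c1cc2nc(N)nc(N)c2cc1C` gives 11.1 nM, and compound 2 `CCOc1ccc(C=O)cc1-c1cc2nc(N)nc(N)c2cc1C` gives 12 nM. Compound 3 `Nc1nc(N)c2ccc(-c3ccccc3)cc2n1`, which lacks the ethoxy-bearing ring substituents and the methyl, gives 743 nM. On these numbers compound 2 sits second highest of three; its nearest neighbour is compound 1, within the scatter, and the furthest is compound 3, beyond the scatter.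

One step between measured compounds is defined: a 1.1-fold higher number from compound 1 to compound 2 (0.03 log units; within the scatter), a formyl in place of chloro on an aromatic carbon, so the exchange at that position left the number essentially unchanged.

Compound 4 `CCOc1ccc(C(=O)N(CC)CC)cc1-c1cc2nc(N)nc(N)c2cc1C` is not yet measured. It differs from compound 2 by diethylamino in place of hydrogen on a carbonyl carbon; cut one bond further out, the change reads formyl to diethylcarbamoyl. For the measured compounds named here, the only step that bears on it is the one from compound 1 to compound 2, which also altered this same position and stayed within the scatter. Going by the values given here, no measured step tests a diethylamino group anywhere, so the direction is open.

The expectation for compound 4 in this assay is therefore no step beyond the scatter, a 1.3-fold higher number from compound 2 to compound 4 (0.10 log units; within the scatter). Compound 4 is estimated at 15 nM, with a range from 5 nM to 45 nM.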

Compound 4, inhibition constant: 34 nM
Compound 4: the middle estimate sits 2.3-fold (0.36 log units) below what was measured; low and high end bracket the measured number.
By their numbers in this assay, from the lowest: compounds 1 and 2 (each within the scatter of the next); then compound 4; then compound 3.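

In this assay, the place that showed no response to the earlier exchange now does: a 2.8-fold higher number from compound 2 to compound 4 (0.45 log units; beyond the scatter), and a 3.1-fold higher number from compound 1 to compound 4 (0.49 log units; beyond the scatter). For the compounds shown here, the earlier step, a 1.1-fold higher number from compound 1 to compound 2 (0.03 log units; within the scatter), showed only that chloro and formyl could stand in for each other on this aromatic carbon, whereas diethylamino on the carbonyl carbon gives the first change at this place that lies beyond the scatter, though both new steps remain modest. No measurement on hand explains this shift.

With a diethylcarbamoyl group as the only amide at this place, nothing separates a contribution of the amide link itself from one of the ethyl chains. A primary carboxamide, a dimethylcarbamoyl group or a carboxylic acid on the same aromatic carbon would show whether the number stays close to that of compound 2, moves towards that of compound 4, or goes further.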